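The source may report more compounds than this note shows. Statements on the series, on what has been measured and on what is new or still open speak of the compounds shown alone.

The measured compounds, in a functional assay on MDA-MB-231 cells (Homo sapiens) for antiproliferative activity, read by MTT assay, with a stated time of 24 h; a lower number here means a stronger inhibitor, a higher number a weaker inhibitor:

Compound 1 `COc1ccc(-c2cc(C(=O)/C=C/c3ccccc3)nc3cc(-c4ccccc4)nn23)cc1OC` gives 23300 nM.
Compound 2 `COc1ccc(/C=C/C(=O)c2cc(-c3ccc(OC)c(OC)c3)n3nc(-c4ccccc4)cc3n2)cc1` gives 22000 nM.
Compound 3 `COc1cc(-c2cc(C(=O)/C=C/c3ccc(Cl)cc3)nc3cc(-c4ccccc4)nn23)cc(OC)c1OC` gives 21600 nM.

All three numbers sit within the scatter of one another in this assay, so compound 3 is not set apart from compound 2 or compound 1 by the data shown; the three behave as one group on this read-out.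

Compound 4 `COc1ccc(-c2cc(C(=O)/C=C/c3ccc(Cl)cc3)nc3cc(-c4ccccc4)nn23)cc1OC` differs from compound 3 by hydrogen in place of methoxy on an aromatic carbon. Going by the values given here, only one measured step touches a methoxy on an aromatic carbon: a 1.1-fold lower number from compound 1 to compound 2 (0.02 log units; within the scatter), which runs in the opposite direction to the present change and sits on a different ring of the shared core. That step is within the scatter, and the three measured values themselves show no spread beyond the scatter, so nothing in the data points to a change in either direction.

Compound 4 is therefore expected to give a number close to that of compound 3, with a 1.0-fold higher number from compound 3 to compound 4 (0.01 log units; within the scatter) as the expected step. The estimate for compound 4 in this assay is 22000 nM, within a range from 11000 nM to 44000 nM.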

Compound 4, half-maximal inhibitory concentration: 23700 nM
Compound 4: the middle estimate sits 1.1-fold (0.03 log units) below what was measured; the measured number falls inside the stated range.
By their numbers in this assay, from the lowest: compounds 3, 2, 1 and 4 (each within the scatter of the next).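

In this assay, going from the 3,4,5-trimethoxyphenyl group to the 3,4-dimethoxyphenyl group gives a 1.1-fold higher number from compound 3 to compound 4 (0.04 log units; within the scatter), so at this position, with chloro present elsewhere in the molecule, hydrogen and methoxy cannot be told apart. The chloro-bearing compound 4 also stays level with the two compounds without chloro, with chloro in place of methoxy giving (a 1.1-fold higher number from compound 2 to compound 4 (0.03 log units; within the scatter)) and chloro in place of hydrogen giving (a 1.0-fold higher number from compound 1 to compound 4 (0.01 log units; within the scatter)). Methoxy in place of hydrogen thus leaves the number unchanged within the scatter in both places where it can be read: the same change on two cores in this assay, a 1.1-fold lower number (0.02 log units; within the scatter) from compound 1 to compound 2 and a 1.1-fold lower number (0.04 log units; within the scatter) from compound 4 to compound 3, 1.0-fold (0.02 log units) apart, within the scatter of two such steps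

The compounds shown carry only methoxy or hydrogen at this position, so they leave open whether any other group there could move the number beyond the scatter. An amine, a carboxylic acid or a longer alkoxy chain at this place would put that question to the test.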